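Amino alcohol series: chain length and amine-carbon branching

The compounds below may be only part of what the source reports. "The series", "measured", "known", "first", "only" and "open" are said of these compounds alone.

Compound 1 `CCCCCCCCC[C@@H](O)[C@H](C)N` gives 9500 nM in a functional assay on SW1573 cells (Homo sapiens) for antiproliferative activity, read by sulforhodamine B assay, with a stated time of 48 h; on this read-out lower numbers stand for stronger inhibition of growth and higher numbers for weaker inhibition of growth. Compound 2 `CCCCCCCCC[C@@H](O)[C@@H](N)[C@@H](C)CC` differs from compound 1 by sec-butyl in place of methyl on a saturated chain carbon bound to an amine nitrogen and a saturated chain carbon; in this assay compound 2 gives 13000 nM, and the step is a 1.4-fold higher number from compound 1 to compound 2 (0.14 log units; within the scatter). Compound 3 `CCCCCCCCCCCCCCC[C@@H](O)[C@H](C)N` differs from compound 1 by hexyl in place of hydrogen on a saturated chain carbon, ten or more bonds along the chain from an oxygen on a saturated carbon; in this assay compound 3 gives 1300 nM, the step being a 7.3-fold lower number from compound 1 to compound 3 (0.86 log units; beyond the scatter). Compound 4 `CCCCCCCCCCCCCCC[C@@H](O)[C@@H](N)[C@@H](C)CC` has not been measured in this assay. It differs from compound 3 by sec-butyl in place of methyl on a saturated chain carbon bound to an amine nitrogen and a saturated chain carbon, the same change as that from compound 1 to compound 2, now made on the core of compound 3, whose difference from the core of compound 1 is given by hexyl in place of hydrogen on a saturated chain carbon, ten or more bonds along the chain from an oxygen on a saturated carbon. Because a 1.4-fold higher number from compound 1 to compound 2 (0.14 log units; within the scatter) lay within the scatter, the expected step is a 1.4-fold higher number from compound 3 to compound 4 (0.14 log units; within the scatter), resting on that single earlier pair alone. Compound 4 is estimated at 1800 nM, with a range of 700 nM to 5000 nM.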

Compound 4, concentration for 50% growth inhibition: 3400 nM
Estimate against measurement, compound 4: 1.9-fold (0.28 log units) below; the range from low to high includes it.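

In this assay, sec-butyl in place of methyl gives a 2.6-fold higher number from compound 3 to compound 4 (0.42 log units; beyond the scatter), and this change carries from one core to the other without a distinguishable difference: the same change on two cores in this assay, a 1.4-fold higher number (0.14 log units; within the scatter) from compound 1 to compound 2 and a 2.6-fold higher number (0.42 log units; beyond the scatter) from compound 3 to compound 4, 1.9-fold (0.28 log units) apart, within the scatter of two such steps. The hexyl change, read on the sec-butyl pair, gives a 3.8-fold lower number from compound 2 to compound 4 (0.58 log units; beyond the scatter), and it also carries over: the same change on two cores in this assay, a 7.3-fold lower number (0.86 log units; beyond the scatter) from compound 1 to compound 3 and a 3.8-fold lower number (0.58 log units; beyond the scatter) from compound 2 to compound 4, 1.9-fold (0.28 log units) apart, within the scatter of two such steps. Within the data shown here, each comparison rests on only two cores, so this shows agreement within this small set, but not that either change would transfer to other cores, nor why the numbers move.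

Still open, on these data alone, is whether a phenyl or isopropyl group in place of sec-butyl would follow the same step. Also open, as far as these compounds go, is whether a longer chain than that of compound 3 would lower the number further.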